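Mouse plasma free fraction: a fluoro-to-hydrogen pair

The source may report more compounds than this note shows. Statements on the series, on what has been measured and on what is new or still open speak of the compounds shown alone.

Measured so far in an ADME assay on a cell-free system (plasma, Mus musculus) for protein binding; on this read-out lower numbers stand for a smaller free fraction and higher numbers for a larger free fraction:
compound 1 `CC(C)COc1ncc(-c2cn(C)c3cc(C(=O)NS(C)(=O)=O)ccc23)cc1Cl`, 0.002
compound 2 `CC(C)COc1ncc(-c2cn(C)c3cc(C(=O)NS(C)(=O)=O)c(F)cc23)cc1Cl`, 0.002
compound 3 `Cn1cc(-c2ccc(C(F)(F)F)cc2)c2cc(F)c(C(=O)NS(C)(=O)=O)cc21`, 0.005

Compound 2 and compound 1 differ only by hydrogen in place of fluoro on an aromatic carbon, and in this assay the step is no change at the digits printed from compound 2 to compound 1 (within the scatter). Compound 3 carries a different core; the difference between the two cores is not broken down here, and its value in this assay stands higher than those of compound 1 and compound 2.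

Compound 4 `Cn1cc(-c2ccc(C(F)(F)F)cc2)c2ccc(C(=O)NS(C)(=O)=O)cc21` is not yet measured. It differs from compound 3 by hydrogen in place of fluoro on an aromatic carbon, the same change as from compound 2 to compound 1. Because that earlier step was no change at the digits printed from compound 2 to compound 1 (within the scatter), the step expected for compound 4 in this assay is no change at the digits printed from compound 3 to compound 4 (within the scatter). Compound 4 is therefore estimated at 0.005, with a range of 0.0025 to 0.01.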

Compound 4, unbound fraction: < 0.001
Compound 4 was reported as a limit; the forecaster's own chance of this, stated with the estimate: 5%; at least 5.0-fold (0.69 log units) between middle value and limit.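

In this assay hydrogen in place of fluoro on an aromatic carbon gives an at least 5.0-fold lower number from compound 3 to compound 4 (0.69 log units; beyond the scatter) and the step does not carry over unchanged from one core to the other: the same change on two cores in this assay, no change at the digits printed (within the scatter) from compound 2 to compound 1 and an at least 5.0-fold lower number (0.69 log units; beyond the scatter) from compound 3 to compound 4, at least 5.0-fold (0.69 log units) apart, beyond the scatter of two such steps
Compound 4 stands at < 0.001 which is a limit of the assay and not a number, so the full size of its step stays unknown: the limit of < 0.001 in this assay, at which 1 of the 4 values shown sits.
These two pairs show that the outcome of this change differs between these two cores, but they do not show which part of the cores accounts for the difference, and they set no rule for any other core.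

Open, going by these compounds, is how chloro or methoxy at the same aromatic carbon would behave on either core. Also open, on these data alone, is whether the gap between the two steps would persist with a carboxylic acid in place of the (methylsulfonyl)carbamoyl group.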